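A Hydroxylated Lactone Variant within the Shared Core Series

The source may report more compounds than this note shows. Statements on the series, on what has been measured and on what is new or still open speak of the compounds shown alone.

Compound 2 `CC1=CC(=O)OC(CSc2nc(-c3ccccc3)c(-c3ccccc3)[nH]2)C1` stands second highest of three numbers in an assay on microsomes from liver for inhibition of sterol O-acyltransferase 1 (Rattus norvegicus) (a lower number here means a stronger inhibitor, a higher number a weaker inhibitor), where compound 2 gives 200 nM. Compound 1 `C[C@]1(O)CC(=O)OC(CSc2nc(-c3ccccc3)c(-c3ccccc3)[nH]2)C1` gives 140 nM, within the scatter of compound 2, while compound 3 `CC1=CC(=O)OC(CSc2nc(-c3cccc(Cl)c3)c(-c3cccc(Cl)c3)[nH]2)C1` gives 440 nM, beyond it. The new compound 4 `O=C1CC(O)CC(CSc2nc(-c3ccccc3)c(-c3ccccc3)[nH]2)O1` carries a group of 8 heavy atoms (5 carbon, 3 oxygen; one six-membered non-aromatic ring with 1 hetero atom) in place of a group of 8 heavy atoms (6 carbon, 2 oxygen; one six-membered non-aromatic ring with 1 hetero atom), on a saturated chain carbon bound to a sulfur. Going by the values given here, the only measured step on this part of the shared core is a 1.4-fold higher number from compound 1 to compound 2 (0.15 log units; within the scatter), which stayed within the scatter, so adding an oxygen and saturating the six-membered ring did not shift the number much. Among the compounds with values here, no measured step removes the methyl group of compound 2, so that part remains untested. Compound 4 is therefore expected to show a step of a 1.1-fold higher number from compound 2 to compound 4 (0.04 log units; within the scatter), with an estimated value of 220 nM, in a range from 90 nM to 500 nM.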

Compound 4, half-maximal inhibitory concentration: 910 nM
Compound 4: the middle estimate sits 4.1-fold (0.62 log units) below what was measured; the measured number lies above the stated range.
By their numbers in this assay, from the lowest: compounds 1 and 2 (each within the scatter of the next); then compound 3; then compound 4.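

Until now, changing the group on this saturated chain carbon bound to a sulfur had stayed within the scatter, but in this assay the position proves sensitive, with a 4.6-fold higher number from compound 2 to compound 4 (0.66 log units; beyond the scatter) beyond it. Compound 4 keeps the hydroxyl group of compound 1 but lacks its methyl group, and a 6.5-fold higher number from compound 1 to compound 4 (0.81 log units; beyond the scatter) shows that the hydroxyl group alone does not hold the number down. No measurement shown here explains this rise. Going by these compounds, whether an ethyl group in the methyl's place would restore the number remains open. So does the effect of an amine in place of the hydroxyl group.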